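Chloro on the phenyl of compound 2

This account rests on a few compounds, and the source may have more. Where it says the series, first, only, none or still open, it means among the compounds named here.

In a functional assay on Bel-7402 cells (Homo sapiens) for inhibition, read by MTT assay, with a stated time of 24 h, tested at 1 ug/mL (a higher number here means more inhibition of growth at the concentration tested, a lower number less inhibition of growth), compound 1 `O=C(CCCCC(S)CCS)NO` gives 9.12% as its reading, and compound 2 `CC(=O)SCCC(CCCCC(=O)Nc1ccccc1)SC(C)=O` gives 2.84% as its reading. These two values lie within the usual scatter of each other, so compound 2 cannot be separated from compound 1 on these numbers. Compound 3 `CC(=O)SCCC(CCCCC(=O)Nc1ccc(Cl)cc1)SC(C)=O` carries one change from compound 2: chloro in place of hydrogen on an aromatic carbon with chloro in place of hydrogen on an aromatic carbon, para to a large group. Going by the values given here, no measured pair shows a step of this kind. The expectation therefore rests on compound 2 at 2.84% as the starting point and is for no step beyond the scatter in this assay in either direction. The expected a number 2.2 percentage points higher from compound 2 to compound 3 (within the scatter) stays small. Compound 3 is estimated at 5% with 0% to 16% as the expected range.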

Compound 3, percent growth inhibition at one concentration: 3.07%
Beside the measured number, compound 3's estimate is 1.9 percentage points above it, within the range that was stated.
By their numbers in this assay, from the lowest: compounds 2, 3 and 1 (each within the scatter of the next).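

Going by these compounds alone, the step from phenyl to 4-chlorophenyl reads a number 0.2 percentage points higher from compound 2 to compound 3 (within the scatter) in this assay, and it is the first pair that differs in one place. On an aromatic carbon para to a large group, chloro therefore cannot be separated from hydrogen on this read-out, with compound 2 at 2.84% and compound 3 at 3.07%. No measurement is available that would explain this result.

Going by these compounds, whether another group at this position, such as an amine, a methoxy group or a carboxylic acid, would give a step beyond the scatter remains open. Also open, on these data alone, are chloro elsewhere on the same ring and how compound 2 and compound 3 would compare at other concentrations.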